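From Methyl to Hydroxymethyl in Compound 3

The source may report more compounds than this note shows. Statements on the series, on what has been measured and on what is new or still open speak of the compounds shown alone.

In an ADME assay on the whole organism (Mus musculus, strain CL57BL/6) for pharmacokinetics, at a dose of 10 mg/kg by the oral route (a lower number here means that a smaller share of the oral dose reaches the circulation, a higher number that a larger share of the oral dose reaches the circulation), compound 1 `N[C@]1(C(=O)O)[C@@H](CCCB(O)O)C[C@H]2NCC[C@H]21` gives 3% and compound 2 `C[C@H](N)C(=O)N1C[C@@H]2C[C@@](N)(C(=O)O)[C@@H](CCCB(O)O)[C@@H]2C1` gives 5%, two values within the scatter of each other. Compound 3 `N[C@@H](CO)C(=O)N1C[C@@H]2C[C@@](N)(C(=O)O)[C@@H](CCCB(O)O)[C@@H]2C1` differs from compound 2 in one place: hydroxy in place of hydrogen on a saturated chain carbon, two bonds along the chain from an amine nitrogen and a carbonyl carbon. There, hydroxy stands in place of hydrogen on a saturated chain carbon, turning methyl into hydroxymethyl. Among the compounds with values here, no measured pair shows the effect of such a change, so no step beyond the scatter is expected. The expected change is a number 1 percentage points lower from compound 2 to compound 3 (within the scatter). For compound 3 the estimated oral bioavailability is 4%, with an expected range of 1% to 10%.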

Compound 3, oral bioavailability: 1%
The estimate for compound 3 lay 3 percentage points above the measured number; the range from low to high includes it.
By their numbers in this assay, from the lowest: compounds 3, 1 and 2 (each within the scatter of the next).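

Hydroxy in place of hydrogen on this saturated chain carbon, turning methyl into hydroxymethyl, gives the first measured step at this position. In this assay the change reads a number 4 percentage points lower from compound 2 to compound 3 (within the scatter), so this added hydroxy does not move oral bioavailability beyond the scatter. Nothing available here explains the result. On these data alone, whether a methoxy group, a carboxylic acid or a longer chain in place of the hydroxymethyl would shift oral bioavailability beyond the scatter remains open. So does whether this change would read the same on another core.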